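Series notes: expected cytotoxicity of compound 3

The compounds below may be only part of what the source reports. "The series", "measured", "known", "first", "only" and "open" are said of these compounds alone.

Compound 2 `O=C(Nc1ccc2nc(NC(=O)C3CCCCC3)sc2c1)c1ccc(Cl)cc1Cl` has been run in a functional assay on WI-38 VA13 cells (Homo sapiens) for cytotoxicity; a lower number here means that less compound is needed, a higher number that more compound is needed for the effect. In this assay compound 2 gives only a limit, > 4 ug/mL. Compound 1 `O=C(Nc1ccc2nc(NC(=O)C3CCCCC3)sc2c1)c1cccc(Oc2ccccc2)c1` likewise returns only a limit in this assay, > 4 ug/mL. Within the data shown here, both measured values sit at the limit of > 4 ug/mL in this assay, at which 2 of the 2 values shown sit, so no step between measured compounds can be stated. Compound 3 `Cc1cccc(C)c1NC(=O)Nc1ccc2nc(NC(=O)C3CCCCC3)sc2c1` remains to be measured in this assay; it differs from compound 2 by (2,6-dimethylphenyl)amino in place of 2,4-dichlorophenyl on a carbonyl carbon. Compound 3 is expected to show a step that the limit leaves unreadable from compound 2 to compound 3, that is, no step beyond the scatter. The estimate for compound 3 in this assay is 6 ug/mL, ranging from 3 ug/mL to 20 ug/mL.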

Compound 3, half-maximal effective concentration: 0.56 ug/mL
Compound 3: middle estimate off by 11-fold (1.03 log units), on the high side; the whole stated range lies above it.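

In this assay, (2,6-dimethylphenyl)amino in place of 2,4-dichlorophenyl on a carbonyl carbon gives an at least 7.1-fold lower number from compound 2 to compound 3 (0.85 log units; beyond the scatter). Among these compounds, the group on this carbonyl carbon can therefore shift the read-out beyond the scatter, which the earlier compounds could not show. Compound 2 gives only a limit, so the step is a bound and not a size: the limit of > 4 ug/mL in this assay, at which 2 of the 3 values shown sit.

Still open, on these data alone, is whether the entering nitrogen or the methyl groups carry the step. A plain phenylamino or a (2,4-dichlorophenyl)amino group on the same carbonyl carbon would separate the two.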